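Replacing benzyl by butoxy on the aryl urea

A few compounds are considered here, and "the series" means these few. Any claim that something is new, unique, unknown or untested is made for them only; others in the source may bear on it.

Measured compounds:
- compound 1, `O=C(Nc1ccc(Cc2ccccc2)cc1)Nc1nn(C(=O)Nc2ccc(Cc3ccccc3)cc2)c2ccccc12`: in a functional assay on MDA-MB-435 cells (Homo sapiens) for inhibition, read by sulforhodamine B assay, with a stated time of 48 h (a lower number here means a stronger inhibitor of growth, a higher number a weaker inhibitor of growth), compound 1 reports only a limit, > 100000 nM
- compound 2, `Nc1nn(C(=O)Nc2ccc(Cc3ccccc3)cc2)c2ccccc12`: in this assay compound 2 gives 2820 nM

For the measured compounds named here, compound 2 carries the only numerical value in this assay; the other entry is a limit, (the limit of > 100000 nM in this assay, at which 1 of the 2 values shown sits). Compound 2 therefore stands alone as the reference point, with nothing measured on either side of it.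

Compound 3, `CCCCOc1ccc(NC(=O)n2nc(N)c3ccccc32)cc1`, has not yet been measured. It differs from compound 2 by butoxy in place of benzyl on an aromatic carbon. Going by the values given here, no step between two measured compounds bears on this change, so its size and direction cannot be read from the present values. A modest shift within or slightly beyond the scatter is expected, in either direction, rather than a large one; the step from compound 2 to compound 3 is estimated as a 1.4-fold higher number from compound 2 to compound 3 (0.15 log units; within the scatter). For compound 3 in this assay the expected value is 4000 nM, with a range from 1000 nM to 20000 nM.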

Compound 3, concentration for 50% growth inhibition: 19100 nM
The estimate for compound 3 lay 4.8-fold (0.68 log units) below the measured number; the measured number falls inside the stated range.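

In this assay, the substituent on the aromatic carbon para to a large group clearly affects growth inhibition: butoxy in place of benzyl gives a 6.8-fold higher number from compound 2 to compound 3 (0.83 log units; beyond the scatter). For the compounds shown here, this is the first step measured at this position, and it lies beyond the scatter, with compound 2 the stronger inhibitor of growth of the pair. No measurement shown gives a cause for this step.

The change removes the aromatic ring of benzyl and introduces a ring-free chain bearing an oxygen in a single move, so the contribution of each remains unresolved. A phenoxy group would keep the oxygen and a ring, and a pentyl chain would have neither the oxygen nor a ring, so either could help separate these contributions at this position.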